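The source may hold more compounds than are shown below. What is called first, only, known or untested is meant among the compounds shown, and "the series" means these compounds.

Measured so far in a physicochemical assay for lipophilicity; on this read-out higher numbers stand for higher lipophilicity and lower numbers for lower lipophilicity: compound 1 `COc1c(OC)c(OC(C)=O)c2ccccc2c1OC(C)=O` gives 2.39; compound 2 `CCCC(=O)Oc1c(OC)c(OC)c(OC(=O)CCC)c2ccccc12` gives 4.64; compound 3 `COc1c(OC)c(OC(C)=O)c2c(Cl)cccc2c1OC(C)=O` gives 3.16.

Compound 2 stands highest of the three, and how its core differs from the core of compound 1 is not broken down here. Compound 3 differs from compound 1 by a single change, (chloro in place of hydrogen on an aromatic carbon), and this brought a number 0.77 log units higher from compound 1 to compound 3 (beyond the scatter).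

Compound 4 `CCCC(=O)Oc1c(OC)c(OC)c(OC(=O)CCC)c2cc(Cl)ccc12` has not yet been measured. It differs from compound 2 by chloro in place of hydrogen on an aromatic carbon, the same kind of change, though here the aromatic carbon is meta to a fused ring and para to a fused ring rather than ortho to a fused ring and meta to a fused ring. Since the earlier step was a number 0.77 log units higher from compound 1 to compound 3 (beyond the scatter), a step of similar size is expected here: a number 0.71 log units higher from compound 2 to compound 4 (beyond the scatter). For compound 4 the estimate in this assay is 5.35, expected to lie between 4.9 and 5.8.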

Compound 4, partition coefficient: 5.5
Compound 4: the middle estimate sits 0.15 log units below what was measured, within the range that was stated.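

When chloro replaces hydrogen on an aromatic carbon, the number moves the same way on both cores in this assay: a number 0.86 log units higher from compound 2 to compound 4 (beyond the scatter) and a number 0.77 log units higher from compound 1 to compound 3 (beyond the scatter). Among the compounds shown here, this is only two pairs, however, and the chloro sits in different places: ortho to a fused ring and meta to a fused ring in compound 3, but meta to a fused ring and para to a fused ring in compound 4, so the effects of place and core cannot be separated. Nothing available here explains either step.

Going by these compounds, it remains open how chloro would behave at the same place on both cores. On these data alone, it also remains open whether another group, such as fluoro, methyl, an amine or a carboxylic acid, would carry from one core to the other in the same way.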